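The source may hold more compounds than are shown below. What is called first, only, known or untested is meant among the compounds shown, and "the series" means these compounds.

Measured in a functional assay on HT-29 cells (Homo sapiens) for antiproliferative activity; on this read-out higher numbers stand for weaker inhibition and lower numbers for stronger inhibition:
- Compound 1 `COc1ccc(S(=O)(=O)N2CCc3cccc(Nc4ccccc4)c32)cc1`: 343 nM
- Compound 2 `COc1ccc(Nc2cccc3c2N(S(=O)(=O)c2ccc(OC)cc2)CC3)cc1`: 803 nM
- Compound 3 `COc1ccc(S(=O)(=O)N2CCc3cccc(Nc4ccc(Cl)cc4)c32)cc1`: 658 nM

The value of compound 3 lies within the scatter of the values of both other compounds. Compound 4 `COc1ccc(S(=O)(=O)N2CCc3cccc(Nc4ccc(F)cc4)c32)cc1` differs from it by one change, (fluoro in place of chloro on an aromatic carbon), which puts fluoro in place of chloro on an aromatic carbon, para to a large group. Within the data shown here, no fluoro compound has been measured yet. The nearest evidence comes from the same place on the ring: a 1.9-fold higher number from compound 1 to compound 3 (0.28 log units; within the scatter) and a 1.2-fold lower number from compound 2 to compound 3 (0.09 log units; within the scatter). Only a 2.3-fold higher number from compound 1 to compound 2 (0.37 log units; beyond the scatter) exceeds the scatter, and modestly. No step beyond the scatter is therefore expected in this assay. The expected step is a 1.3-fold lower number from compound 3 to compound 4 (0.12 log units; within the scatter). Compound 4 is estimated at 500 nM, with an expected range of 250 nM to 1000 nM.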

Compound 4, half-maximal inhibitory concentration: 588 nM
The estimate for compound 4 lay 1.2-fold (0.07 log units) below the measured number, and the stated range covers the measured number.
By their numbers in this assay, from the lowest: compounds 1, 4, 3 and 2 (each within the scatter of the next, the first and the last beyond it).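

In this assay, changing the group at this place to fluoro gives a 1.1-fold lower number from compound 3 to compound 4 (0.05 log units; within the scatter) and a 1.4-fold lower number from compound 2 to compound 4 (0.14 log units; within the scatter), so fluoro cannot be told apart from chloro or methoxy here. Fluoro in place of hydrogen gives a 1.7-fold higher number from compound 1 to compound 4 (0.23 log units; within the scatter), so among the three groups, methoxy alone has a step from hydrogen beyond the scatter. Nothing available explains these small steps.

As far as these compounds go, whether an amine or a carboxylic acid at this place, para to a large group, would shift the number further remains open.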